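The compounds below may be only part of what the source reports. "The series", "measured", "known", "first", "only" and "open" are said of these compounds alone.

Measured compounds:
compound 1 `CCCCNS(=O)(=O)c1ccc(Nc2ncc3c(n2)N(C2CCCC2)[C@H](CC)C(=O)N3C)cc1` — 225 nM
compound 2 `CCCCNS(=O)(=O)c1ccc(Nc2ncc3c(n2)N(c2ccn(C)n2)C(CC)C(=O)N3C)cc1` — 3750 nM
compound 3 `CC[C@@H]1C(=O)N(C)c2cnc(Nc3ccc(S(N)(=O)=O)cc3)nc2N1C1CCCC1` — 1300 nM

All three were run in a functional assay on Huh-7 cells (Homo sapiens) for antiproliferative activity, read by CCK-8 assay, with a stated time of 72 h; on this read-out higher numbers stand for weaker inhibition of growth and lower numbers for stronger inhibition of growth. Compound 1 gives 225 nM in this assay, and compound 3 gives 1300 nM. The two differ in a single place, (hydrogen in place of butyl on a sulfonamide nitrogen), and the step is a 5.8-fold higher number from compound 1 to compound 3 (0.76 log units; beyond the scatter). Compound 2 carries a different core; the difference between the cores of compound 1 and compound 2 is not broken down here. In this assay compound 2 gives 3750 nM, the highest of the three numbers, with its gap to compound 3 and its gap to compound 1 both beyond the scatter.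

Compound 4 `CCC1C(=O)N(C)c2cnc(Nc3ccc(S(N)(=O)=O)cc3)nc2N1c1ccn(C)n1` is not yet measured. It stands to compound 2 as compound 3 stands to compound 1: the change is hydrogen in place of butyl on a sulfonamide nitrogen, on the same place, so it is the same change seen once already. Within the data shown here, the only guide to its size is the measured pair, where compound 1 to compound 3 gave a 5.8-fold higher number from compound 1 to compound 3 (0.76 log units; beyond the scatter). Among the measured compounds shown here, the step from compound 2 to compound 4 in this assay is expected to be of similar size, a 4.8-fold higher number from compound 2 to compound 4 (0.68 log units; beyond the scatter), on the one precedent alone, with the caveat that the cores differ and the transfer is untested. Compound 4 is therefore expected to give about 18000 nM in this assay, within an estimated range from 7000 nM to 50000 nM.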

Compound 4, concentration for 50% growth inhibition: "not active" (no number reported)
Compound 4 has no reported number here; no gap can be computed for the estimate.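

Among these compounds, compound 4 is reported as "not active" in this assay, without a number, so no step from compound 2 to compound 4 can be read. Nothing measured here bears on this result. The compounds shown leave open whether hydrogen in place of butyl on the sulfonamide nitrogen gives a step of similar size on the core of compound 2 and on the core of compound 1.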